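Chlorine shifted within the phenyl on the shared core

This account rests on a few compounds, and the source may have more. Where it says the series, first, only, none or still open, it means among the compounds named here.

Among the compounds with values here, compound 2 `Cn1cnc2c(N3CCCCC3)nc(-c3cccc(Cl)c3)nc21` gives 24.2% in an assay on cells for displacement of a labelled ligand from adenosine receptor A2b (Homo sapiens), read by scintillation counting and radioligand binding, with a stated time of 30 min, tested at 10 uM (a lower number here means less inhibition, a higher number more inhibition at the concentration tested (going by the name of the read-out)), the lowest of the two numbers so far, while compound 1 `Cn1cnc2c(N3CCCCC3)nc(-c3cccc(O)c3O)nc21` gives 26%; the step of a number 1.8 percentage points lower from compound 1 to compound 2 (within the scatter) lies within the scatter, so the two cannot be ordered. Compound 3 `Cn1cnc2c(N3CCCCC3)nc(-c3ccccc3Cl)nc21` remains to be measured. Compared with compound 2, the difference is 2-chlorophenyl in place of 3-chlorophenyl on an aromatic carbon. Within the data shown here, no measured step moves the chlorine within the phenyl ring. Among the measured compounds shown here, the only step on record, a number 1.8 percentage points lower from compound 1 to compound 2 (within the scatter), exchanges 2,3-dihydroxyphenyl for 3-chlorophenyl and itself stays within the scatter, so it bears on the present change only loosely and gives no direction. The expectation is therefore a step no larger than the scatter, estimated as a number 0.8 percentage points higher from compound 2 to compound 3 (within the scatter). Compound 3 is expected to give 25%, with a range from 10% to 40%.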

Compound 3, a percentage reported as inhibition, at one concentration (the size of the read-out at that concentration, not a potency): 32.7%
Beside the measured number, compound 3's estimate is 7.7 percentage points below it; low and high end bracket the measured number.
By their numbers in this assay, from the lowest: compounds 2, 1 and 3 (each within the scatter of the next).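

Moving the chlorine gives the first step at this position in which the atoms stay the same and only their joining differs: in this assay it reads a number 8.5 percentage points higher from compound 2 to compound 3 (within the scatter) and so does not separate the two placements. The exchange of 2,3-dihydroxyphenyl for 2-chlorophenyl reads a number 6.7 percentage points higher from compound 1 to compound 3 (within the scatter) and does not separate those two compounds either, so neither chlorine placement can be told from the dihydroxyphenyl at the tested concentration. Nothing at hand explains the numbers in this small set.

Open, going by these compounds, is whether an aminomethyl or a carboxylic acid on this phenyl, or a longer chain such as butyl in place of the phenyl, would give a step beyond the scatter. Also open, on these data alone, is how a morpholine in place of the piperidin-1-yl group would read with either chlorophenyl.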